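Adding a Fluoro Group to Compound 1

The source may hold more compounds than are shown below. What is called first, only, known or untested is meant among the compounds shown, and "the series" means these compounds.

- compound 1 `O=C(c1cc2ccccc2o1)N1N=C(c2ccccc2)CC1c1ccc([N+](=O)[O-])cc1`: 4.87 ug/mL
- compound 2 `COc1ccc(C2CC(c3ccccc3)=NN2C(=O)c2cc3ccccc3o2)cc1OC`: 6.89 ug/mL
- compound 3 `O=C(c1cc2ccccc2o1)N1N=C(c2ccccc2)CC1c1ccccc1Cl`: 6.22 ug/mL

In a functional assay on A2780 cells (Homo sapiens) for antiproliferative activity, read by MTT assay, with a stated time of 72 h (on this read-out lower numbers stand for stronger inhibition and higher numbers for weaker inhibition), compound 1 has no clear place among these three: a 1.4-fold higher number from compound 1 to compound 2 (0.15 log units; within the scatter) and a 1.3-fold higher number from compound 1 to compound 3 (0.11 log units; within the scatter) both lie within the scatter. Compound 4 `O=C(c1cc2ccccc2o1)N1N=C(c2ccc(F)cc2)CC1c1ccc([N+](=O)[O-])cc1` changes phenyl to 4-fluorophenyl, with fluoro in place of hydrogen on an aromatic carbon. Among the measured compounds shown here, no measured step touches this place. The nearest evidence comes from swaps of the group on a saturated ring carbon, and even there a 1.4-fold higher number from compound 1 to compound 2 (0.15 log units; within the scatter) stayed within the scatter. No step beyond the scatter is therefore expected, though this rests on indirect evidence. The estimated change is a 1.0-fold higher number from compound 1 to compound 4 (0.01 log units; within the scatter). For compound 4 the estimated value is 5 ug/mL, with an expected range of 2.6 ug/mL to 9.5 ug/mL.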

Compound 4, half-maximal inhibitory concentration: > 50 ug/mL
Compound 4 gave a limit, no number; the forecaster's own chance of this, stated with the estimate: 2%; middle value at least 10-fold (1.00 log units) away from the limit.
By their numbers in this assay, from the lowest: compounds 1, 3 and 2 (each within the scatter of the next). At a limit, above all of these: compound 4.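

The earlier compounds shown here differed only in the group on a saturated ring carbon, and those swaps stayed within the scatter. In this assay, fluoro in place of hydrogen on an aromatic carbon, para to a large group, gives an at least 10-fold higher number from compound 1 to compound 4 (1.01 log units; beyond the scatter), so one atom at this place can count for far more than those swaps did. The result for compound 4 is a limit, not a number: the limit of > 50 ug/mL in this assay, at which 1 of the 4 values shown sits.

The compounds shown carry only hydrogen or fluoro at this place. Going by these compounds, whether a methyl group or an amine here would keep the activity of compound 1 stays open.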